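The compounds below may be only part of what the source reports. "The series", "measured", "known", "first", "only" and "open" are said of these compounds alone.

Measured compounds:
Compound 1, `COc1ccc(CNc2nc([SeH])nc3ccccc23)cc1`, gives in an ADME assay on 184B5 cells (Homo sapiens) for cytotoxicity, read by MTT assay, with a stated time of 72 h (on this read-out lower numbers stand for stronger inhibition of growth and higher numbers for weaker inhibition of growth), a limit rather than a number, > 100000 nM.
Compound 2, `Sc1nc(NCc2ccccc2)c2ccccc2n1`, gives in this assay likewise only a limit, > 100000 nM.

Compound 2 therefore stands at the limit of > 100000 nM in this assay, at which 2 of the 2 values shown sit, and nothing more can be said about its place among the numbers shown. Compound 3, `COc1ccc(CNc2nc(S)nc3ccccc23)cc1`, differs from it by methoxy in place of hydrogen on an aromatic carbon. Going by the values given here, both values shown sit at the same limit, so no step between measured compounds can be sized. Compound 3 is expected to remain at that limit as well, with a step from compound 2 of a step that the limit leaves unreadable from compound 2 to compound 3 that is not expected to exceed the scatter. The estimate for compound 3 in this assay is 150000 nM, between 60000 nM and 400000 nM.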

Compound 3, concentration for total growth inhibition: 36600 nM
Compound 3: the middle estimate sits 4.1-fold (0.61 log units) above what was measured; the measured number lies below the stated range.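

In this assay, compound 3 is the first compound shown to give a number rather than a limit, and methoxy in place of hydrogen, para to a large group, gives an at least 2.7-fold lower number from compound 2 to compound 3 (0.43 log units; beyond the scatter). With that methoxy kept, one sulfur atom in place of one selenium atom gives an at least 2.7-fold lower number from compound 1 to compound 3 (0.43 log units; beyond the scatter), so both single changes register in this assay. Both steps are only lower bounds because each starts from a limit: the limit of > 100000 nM in this assay, at which 2 of the 3 values shown sit.

As far as these compounds go, the true size of either step stays open. So does whether an amine, a carboxylic acid or a longer chain such as ethoxy at this position would move the number further.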